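The source may report more compounds than this note shows. Statements on the series, on what has been measured and on what is new or still open speak of the compounds shown alone.

Within the data shown here, in a functional assay on MGC-803 cells (Homo sapiens) for antiproliferative activity, read by CCK-8 assay, with a stated time of 72 h, tested at 8 uM (on this read-out higher numbers stand for a stronger effect at the one concentration tested and lower numbers for a weaker effect), compound 2 `CN(Cc1cccnc1)C(=S)SCc1ccc(C(=O)Nc2ccccc2N)cc1` gives 85.5%, the larger of the two numbers measured so far, though only by an amount within the usual scatter. Among the measured compounds shown here, its one neighbour, compound 1 `CC1CCN(C(=S)SCc2ccc(C(=O)Nc3ccccc3N)cc2)CC1`, gives 81.9% in the same test, and the single step measured between them, a number 3.6 percentage points higher from compound 1 to compound 2 (within the scatter), lies within the scatter. Compound 3 `Nc1ccccc1NC(=O)c1ccc(CSC(=S)N2CCCC2)cc1` has not yet been measured. It differs from compound 2 in one place: pyrrolidin-1-yl in place of methyl((pyridin-3-yl)methyl)amino on a thiocarbonyl carbon. For the measured compounds named here, the only measured step that bears on this change is a number 3.6 percentage points higher from compound 1 to compound 2 (within the scatter), which also exchanged one amino group for another on the same thiocarbonyl carbon and produced no shift beyond the scatter. With two compounds the evidence is thin, but nothing in it points to a step in either direction for a third amino group at this position. The step expected in this assay is therefore a number 5.5 percentage points lower from compound 2 to compound 3 (within the scatter), which is within the scatter. Compound 3 is accordingly estimated to give 80%, with a range from 62% to 92%.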

Compound 3, a percentage reported as inhibition, at one concentration (the size of the read-out at that concentration, not a potency): 83.4%
For compound 3 the middle estimate is 3.4 percentage points below the measured one; the measured number falls inside the stated range.
By their numbers in this assay, from the lowest: compounds 1, 3 and 2 (each within the scatter of the next).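

In this assay, among these compounds, a third amino group on the thiocarbonyl carbon, pyrrolidin-1-yl, gives a number 2.1 percentage points lower from compound 2 to compound 3 (within the scatter) and a number 1.5 percentage points higher from compound 1 to compound 3 (within the scatter), so all the measured steps at this position now lie inside the scatter and the three compounds cannot be told apart on this read-out. The earlier pair had compared only 4-methylpiperidin-1-yl with methyl((pyridin-3-yl)methyl)amino, whereas this change also replaces the six-membered aromatic ring and its hydrogen-bond acceptor with a five-membered non-aromatic ring, and takes the group from 9 heavy atoms to 5, with no shift beyond the scatter. No measurement on hand offers an explanation for this flat result.

The compounds shown all carry a tertiary amino group on the thiocarbonyl carbon, so it remains open whether a group of another kind there, such as a primary amine, a carboxylic acid or a long straight alkyl chain, would move the number beyond the scatter. On these data alone, since each compound is read at a single concentration, the numbers show only the size of the effect at that concentration, and it also remains open whether the compounds would show a stronger or weaker effect than one another at other concentrations, which a full concentration series in the same cells could show.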